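Working notes: methoxy in place of fluoro on the aryl group

The compounds below may be only part of what the source reports. "The series", "measured", "known", "first", "only" and "open" are said of these compounds alone.

- compound 1 `COc1ccc(S(=O)(=O)N2CCc3cccc(-c4ccc([N+](=O)[O-])cc4)c32)cc1` gives 51.8 nM
- compound 2 `COc1ccc(S(=O)(=O)N2CCc3cccc(-c4ccc(F)cc4)c32)cc1` gives 85.5 nM

For the measured compounds named here, both values come from a functional assay on HT-29 cells (Homo sapiens) for inhibition, with a stated time of 72 h (on this read-out lower numbers stand for stronger inhibition and higher numbers for weaker inhibition), and lie within the scatter of each other, so compound 2 stands level with the only other measured compound (a 1.7-fold higher number from compound 1 to compound 2 (0.22 log units; within the scatter)). Next is compound 3 `COc1ccc(-c2cccc3c2N(S(=O)(=O)c2ccc(OC)cc2)CC3)cc1`, with methoxy in place of fluoro on an aromatic carbon, para to a large group (methoxy in place of fluoro on an aromatic carbon). Going by the values given here, only one measured step bears on this change: fluoro in place of nitro on an aromatic carbon, which stayed within the scatter. Among the compounds with values here, that is thin evidence, and no measured compound carries methoxy there. No step beyond the scatter is therefore expected in this assay, and no firm direction can be given. The expected step remains small (a 1.2-fold lower number from compound 2 to compound 3 (0.09 log units; within the scatter)). For compound 3 the estimated value is 70 nM (expected range 25 nM to 200 nM).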

Compound 3, half-maximal inhibitory concentration: 277 nM
Beside the measured number, compound 3's estimate is 4.0-fold (0.60 log units) below it; measured number outside the range, above it.
By their numbers in this assay, from the lowest: compounds 1 and 2 (each within the scatter of the next); then compound 3.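

In this assay, for the compounds shown here, the change from 4-fluorophenyl to 4-methoxyphenyl gives the first step at this position that lies beyond the scatter (a 3.2-fold higher number from compound 2 to compound 3 (0.51 log units; beyond the scatter)), so the position is not indifferent to the group it carries. Methoxy in place of nitro points the same way (a 5.3-fold higher number from compound 1 to compound 3 (0.73 log units; beyond the scatter)), while nitro and fluoro remain within the scatter of each other, which leaves methoxy as the one group of the three that stands apart, with weaker inhibition. No measurement on hand accounts for this separation.

Open, from the compounds shown here alone, is whether the weaker inhibition belongs to methoxy alone or also extends to a longer ether such as ethoxy, or to a hydroxyl or an amine on the same aromatic carbon. Also open, going by these compounds, is whether the same change would give a similar step with a different sulfonyl aryl group on the shared core.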